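Aryl hydrazone variation on the shared core: compound 4

The source may report more compounds than this note shows. Statements on the series, on what has been measured and on what is new or still open speak of the compounds shown alone.

Measured so far:
- compound 1 `CN(C)CCn1cnnc1-c1cc(Oc2ccc(NC(=O)N/N=C/c3ccc(Cl)cc3Cl)cc2F)ccn1` — 130 nM
- compound 2 `CN(C)CCn1cnnc1-c1cc(Oc2ccc(NC(=O)N/N=C/c3c[nH]c4ccccc34)cc2F)ccn1` — 1630 nM
- compound 3 `CN(C)CCn1cnnc1-c1cc(Oc2ccc(NC(=O)N/N=C/c3ccc(O)c(O)c3)cc2F)ccn1` — 1930 nM

All three were tested in a functional assay on NCI-H460 cells (Homo sapiens) for cytotoxicity, read by MTT assay, with a stated time of 72 h; a lower number here means a stronger inhibitor, a higher number a weaker inhibitor. Compound 3 holds the highest number of the three; compound 2 sits nearest, the gap a 1.2-fold higher number from compound 2 to compound 3 (0.07 log units; within the scatter), while compound 1 is furthest, the gap a 15-fold higher number from compound 1 to compound 3 (1.17 log units; beyond the scatter). The second large step, a 13-fold higher number from compound 1 to compound 2 (1.10 log units; beyond the scatter), shows that the aryl group on the carbon with a double bond to nitrogen carries most of the variation seen.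

Compound 4 `CN(C)CCn1cnnc1-c1cc(Oc2ccc(NC(=O)N/N=C/c3ccc(O)cc3)cc2F)ccn1` differs from compound 3 by hydrogen in place of hydroxy on an aromatic carbon. Within the data shown here, no measured step changes only a hydroxy on this ring; the steps available swap the whole aryl group. The near-equal numbers of compound 2 and compound 3 suggest that two quite different polar aryl groups land together, so a single hydroxy removal is expected to move the number little, if at all beyond the scatter. The expected step for compound 4 is a 1.4-fold lower number from compound 3 to compound 4 (0.14 log units; within the scatter). Compound 4 is therefore estimated at 1400 nM in this assay, with a range of 450 nM to 4500 nM.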

Compound 4, half-maximal inhibitory concentration: 1780 nM
The estimate for compound 4 lay 1.3-fold (0.10 log units) below the measured number; low and high end bracket the measured number.
By their numbers in this assay, from the lowest: compound 1; then compounds 2, 4 and 3 (each within the scatter of the next).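

In this assay, among these compounds, the change from 3,4-dihydroxyphenyl to 4-hydroxyphenyl is the first confined to a single hydroxy on the aryl ring, and it gives a 1.1-fold lower number from compound 3 to compound 4 (0.04 log units; within the scatter), so this hydroxy has no readable effect on the number. Compound 4 also stays level with the 1H-indol-3-yl analogue, a 1.1-fold higher number from compound 2 to compound 4 (0.04 log units; within the scatter), but remains well separated from the 2,4-dichlorophenyl analogue, a 14-fold higher number from compound 1 to compound 4 (1.14 log units; beyond the scatter), leaving compound 1 alone among the four as the outlier. Nothing available explains why the 2,4-dichlorophenyl analogue stands apart.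

Still open, from the compounds shown here alone, is whether the gap to compound 1 comes from the chlorine atoms or from the absence of hydroxy groups; a plain phenyl or a 4-chlorophenyl group on the shared core would separate the two. A methoxy or an amine in place of the remaining hydroxy would show whether that position tolerates other groups.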